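The compounds below may be only part of what the source reports. "The series", "measured", "known", "first", "only" and "open" are said of these compounds alone.

Compound 1 `Cn1nnnc1SCC(=O)Nc1ccc(-c2nc(-c3ccccc3)c(-c3ccccc3)n2C)cc1` gives 84% in a functional assay on HT-29 cells (Homo sapiens) for cytotoxicity, read by MTT assay, with a stated time of 24 h, tested at 32 ug/mL (on this read-out lower numbers stand for a weaker effect and higher numbers for a stronger effect at the one concentration tested), the higher of the two measured numbers, while compound 2 `CCN1CCN(CC(=O)Nc2ccc(-c3nc(-c4ccccc4)c(-c4ccccc4)n3C)cc2)CC1` gives 38.8%. Within the data shown here, the one measured step that bears on the question is a number 45.2 percentage points lower from compound 1 to compound 2 (beyond the scatter), a large fall. Compound 3 `CN(C)/C=C/N1CCN(CC(=O)Nc2ccc(-c3nc(-c4ccccc4)c(-c4ccccc4)n3C)cc2)CC1` differs from compound 1 by 4-(2-(dimethylamino)ethenyl)piperazin-1-yl in place of (1-methyl-1H-tetrazol-5-yl)sulfanyl on a saturated chain carbon bound to a carbonyl carbon. In compound 3, as in compound 2, the (1-methyl-1H-tetrazol-5-yl)sulfanyl group gives way to a substituted piperazin-1-yl, so a drop of similar size is expected: a number 42 percentage points lower from compound 1 to compound 3 (beyond the scatter). Compound 3 is therefore estimated at 42%, with a likely range from 20% to 65%.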

Compound 3, a percentage reported as activity, at one concentration (the size of the read-out at that concentration, not a potency): 29.8%
Compound 3: middle estimate off by 12.2 percentage points, on the high side, within the range that was stated.
By their numbers in this assay, from the lowest: compounds 3 and 2 (each within the scatter of the next); then compound 1.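

In this assay a second substituted piperazin-1-yl on a saturated chain carbon bound to a carbonyl carbon also falls well short of the (1-methyl-1H-tetrazol-5-yl)sulfanyl group, with a number 54.2 percentage points lower from compound 1 to compound 3 (beyond the scatter) as the measured step. Putting 2-(dimethylamino)ethenyl in place of ethyl on the ring amine nitrogen gives a number 9 percentage points lower from compound 2 to compound 3 (within the scatter) as its step, so these two piperazine substituents cannot be told apart here. Nothing measured explains the fall.

Still open, on these data alone, is whether the sulfur link or the tetrazole ring matters more; a phenylsulfanyl or a (1-methyl-1H-imidazol-2-yl)sulfanyl group would help separate the two.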